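This account rests on a few compounds, and the source may have more. Where it says the series, first, only, none or still open, it means among the compounds named here.

Measured compounds in a functional assay on CCRF-CEM cells for antagonist activity at C-X-C chemokine receptor type 4 (Homo sapiens), read by calcium flux, with stated times of 25 min and 90 s; a lower number here means a stronger inhibitor, a higher number a weaker inhibitor:
- compound 1 `C/C(=C/CN(C[C@H]1Cc2ccccc2CN1)[C@H]1CCCc2cccnc21)CN`, which gives 8.6 nM
- compound 2 `N[C@H]1CC[C@H](CN(C[C@H]2Cc3ccccc3CN2)[C@H]2CCCc3cccnc32)CC1`, which gives 280 nM
- compound 3 `C/C(CN(C[C@H]1Cc2ccccc2CN1)[C@H]1CCCc2cccnc21)=C(/F)CN`, which gives 1800 nM

Compound 3 stands highest of the three numbers, beyond the scatter from both others. Compound 4 `NC[C@H]1CC[C@H](CN(C[C@H]2Cc3ccccc3CN2)[C@H]2CCCc3cccnc32)CC1` is not yet measured; it differs from compound 3 by 4-(aminomethyl)cyclohexyl in place of 3-amino-2-fluoro-1-methylprop-1-en-1-yl on a saturated chain carbon bound to an amine nitrogen. Going by the values given here, two measured steps bear on this change. The step of a 6.4-fold higher number from compound 2 to compound 3 (0.81 log units; beyond the scatter) shows that replacing the 4-aminocyclohexyl group by the fluorinated alkene raised the number; the step of a 210-fold higher number from compound 1 to compound 3 (2.32 log units; beyond the scatter) shows the same direction from the non-fluorinated alkene. Compound 4 carries a 4-(aminomethyl)cyclohexyl group, close to compound 2, so a lower number than compound 3 is expected, roughly reversing the modest step above. Compound 4 is therefore estimated at 180 nM, within 45 nM to 700 nM, an expected step of a 10-fold lower number from compound 3 to compound 4 (1.00 log units; beyond the scatter).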

Compound 4, half-maximal inhibitory concentration: 340 nM
Beside the measured number, compound 4's estimate is 1.9-fold (0.28 log units) below it, within the range that was stated.
By their numbers in this assay, from the lowest: compound 1; then compounds 2 and 4 (each within the scatter of the next); then compound 3.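

In this assay, the 4-(aminomethyl)cyclohexyl group gives a clear gain over the fluorinated alkene (a 5.3-fold lower number from compound 3 to compound 4 (0.72 log units; beyond the scatter)). Aminomethyl in place of amino on a saturated ring carbon leaves the number within the scatter (a 1.2-fold higher number from compound 2 to compound 4 (0.08 log units; within the scatter)), so in these two compounds the added carbon makes no readable difference. The gap to the non-fluorinated alkene remains large (a 40-fold higher number from compound 1 to compound 4 (1.60 log units; beyond the scatter)), and this extension of the cyclohexyl amine does not close it.

Going by these compounds, whether a longer aminoethyl chain on the cyclohexyl ring, or a carboxylic acid in place of the amine, would change the number remains open. Nothing given here accounts for any of these steps.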